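The source may report more compounds than this note shows. Statements on the series, on what has been measured and on what is new or still open speak of the compounds shown alone.

Compound 1 `COc1ccc(CCOc2ccc(-c3c(C)nc(C)c([C@H](OC(C)(C)C)C(=O)O)c3N3CCC(C)(C)CC3)cc2)cc1` and compound 2 `Cc1nc(C)c([C@H](OC(C)(C)C)C(=O)O)c(N2CCC(C)(C)CC2)c1-c1ccc(OCCc2ccc(F)c(F)c2)cc1` share one core and differ only in the group hung on the oxygen of the aromatic ring. In an ADME assay on microsomes from liver (Rattus norvegicus) for metabolic stability, read by LC-MS, tested at 0.5 uM (on this read-out lower numbers stand for a shorter-lived compound and higher numbers for a longer-lived compound), compound 1 reaches only a limit of the assay, > 2 h. In this assay compound 2 gives 0.85 h, so that an at least 2.3-fold lower number from compound 1 to compound 2 (0.37 log units; beyond the scatter). Compound 3 `Cc1nc(C)c([C@H](OC(C)(C)C)C(=O)O)c(N2CCC(C)(C)CC2)c1-c1ccc(OC2COCC2c2ccc(F)cc2)cc1` carries a larger change at the same place: 4-(4-fluorophenyl)oxolan-3-yl in place of 2-(4-methoxyphenyl)ethyl on an oxygen on an aromatic ring. Within the data shown here, because compound 1 sits at the limit of > 2 h in this assay, at which 1 of the 2 values shown sits, its true number is unknown, and the only measured step points downward. Compound 3 is therefore expected to give 1.5 h (range 0.6 h to 4 h), a step of an at least 1.3-fold lower number from compound 1 to compound 3 (0.12 log units; that floor lies within the scatter).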

Compound 3, half-life: > 2 h
Compound 3 ended at the assay's limit; the forecaster's own chance of this, stated with the estimate: 30%; middle value at least 1.3-fold (0.12 log units) from the limit.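

In this assay compound 3 gives > 2 h, which is a limit of the assay. Putting 4-(4-fluorophenyl)oxolan-3-yl on this oxygen in place of 2-(3,4-difluorophenyl)ethyl gives an at least 2.3-fold higher number from compound 2 to compound 3 (0.37 log units; beyond the scatter), so a fluorine-bearing group here can still reach the limit. The step between compound 1 and compound 3 cannot be read: the limit of > 2 h in this assay, at which 2 of the 3 values shown sit.

Still open, going by these compounds, is whether the oxolane ring or the loss of one fluorine carries this rise. A 2-(4-fluorophenyl)ethyl group on the same oxygen would help separate the two.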